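A few compounds are considered here, and "the series" means these few. Any claim that something is new, unique, unknown or untested is made for them only; others in the source may bear on it.

The series keeps one core and varies only the ring on the sulfonamide nitrogen. Compound 1 `Cc1noc(NS(=O)(=O)c2ccc(N/C(S)=N\c3ccnc4cc(C(F)(F)F)ccc34)cc2)c1C` gives 36800 nM in a functional assay on HepG2 cells (Homo sapiens) for antiproliferative activity, read by sulforhodamine B assay, with a stated time of 48 h; a higher number here means a weaker inhibitor, a lower number a stronger inhibitor. Compound 2 `O=S(=O)(Nc1nccs1)c1ccc(N/C(S)=N\c2ccnc3cc(C(F)(F)F)ccc23)cc1` gives 28200 nM in this assay. Compound 3 `O=S(=O)(Nc1ncccn1)c1ccc(N/C(S)=N\c2ccnc3cc(C(F)(F)F)ccc23)cc1` gives 42100 nM in this assay; its number is the highest of the three shown, yet each gap to the other two lies within the scatter. The three steps recorded so far, a 1.3-fold lower number from compound 1 to compound 2 (0.12 log units; within the scatter), a 1.1-fold higher number from compound 1 to compound 3 (0.06 log units; within the scatter) and a 1.5-fold higher number from compound 2 to compound 3 (0.17 log units; within the scatter), are all ring swaps at this one position, and none of them moved the number beyond the scatter.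

Compound 4 `COc1cc(NS(=O)(=O)c2ccc(N/C(S)=N\c3ccnc4cc(C(F)(F)F)ccc34)cc2)nc(OC)n1` is the next swap of the same kind: 2,6-dimethoxypyrimidin-4-yl in place of pyrimidin-2-yl on a sulfonamide nitrogen. All three earlier ring swaps at the sulfonamide nitrogen bear on it, and each stayed within the scatter, so in this assay the expected step is a 1.1-fold lower number from compound 3 to compound 4 (0.02 log units; within the scatter), that is, no change beyond the scatter in either direction. The estimate for compound 4 is 40000 nM, with a range from 20000 nM to 80000 nM.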

Compound 4, half-maximal inhibitory concentration: 76700 nM
Compound 4: middle estimate off by 1.9-fold (0.28 log units), on the low side, within the range that was stated.
By their numbers in this assay, from the lowest: compounds 2, 1, 3 and 4 (each within the scatter of the next, the first and the last beyond it).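

In this assay the ring on the sulfonamide nitrogen can now move the number beyond the scatter: a 2.7-fold higher number from compound 2 to compound 4 (0.43 log units; beyond the scatter) and a 2.1-fold higher number from compound 1 to compound 4 (0.32 log units; beyond the scatter) are both modest steps. The separation is incomplete, since a 1.8-fold higher number from compound 3 to compound 4 (0.26 log units; within the scatter) stays within the scatter, so compound 4 parts from compound 1 and compound 2 but not from compound 3. No measured evidence shown here accounts for these steps.

The compounds shown do not separate the effect of the two methoxy groups from that of the change in ring attachment from pyrimidin-2-yl to pyrimidin-4-yl. Also open, as far as these compounds go, is how a ring carrying an amine or a carboxylic acid, or a plain alkyl chain on the sulfonamide nitrogen, would read in this assay on the shared core.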